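Three arylsulfonamides on one core, all at the limit

A few compounds are considered here, and "the series" means these few. Any claim that something is new, unique, unknown or untested is made for them only; others in the source may bear on it.

Measured compounds in a functional assay on KYSE-510 cells (Homo sapiens) for antiproliferative activity, read by crystal violet staining, with a stated time of 96 h; on this read-out lower numbers stand for stronger inhibition of growth and higher numbers for weaker inhibition of growth:
- compound 1 `Cc1ccc(S(=O)(=O)NC2=NCCN2C(=S)SN2CCn3c2nsc3=S)cc1` gives >= 20000 nM, which is a limit of the assay, not a number.
- compound 2 `COc1ccc(S(=O)(=O)NC2=NCCN2C(=S)SN2CCn3c2nsc3=S)cc1` gives >= 20000 nM, also a limit.
- compound 3 `O=S(=O)(NC1=NCCN1C(=S)SN1CCn2c1nsc2=S)c1ccc(Cl)cc1` gives >= 20000 nM, again a limit.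

Compound 3 therefore stands nowhere in particular among the numbers shown: all three compounds sit at the limit of >= 20000 nM in this assay, at which 3 of the 3 values shown sit, and none of them has a readable value. The three measured steps, a step that the two limits leave unreadable from compound 1 to compound 2, a step that the two limits leave unreadable from compound 1 to compound 3 and a step that the two limits leave unreadable from compound 2 to compound 3, are each unreadable for the same reason, so the size of a change on the aromatic ring cannot be read from them.

Compound 4 `O=S(=O)(NC1=NCCN1C(=S)SN1CCn2c1nsc2=S)c1ccc(Cl)c(Cl)c1Cl` has not yet been measured. It differs from compound 3 by 2,3,4-trichlorophenyl in place of 4-chlorophenyl on a sulfonyl sulfur. For the measured compounds named here, the measured steps bear on this change only in that three different groups on the aromatic ring all left the compounds at the limit, which gives no direction and no size for the step in this assay.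

On that basis compound 4 is expected to remain at the limit as well, estimated at 20000 nM with a range from 10000 nM to 60000 nM, the step of a number no higher from compound 3 to compound 4 (the limit leaves the size open) being an expectation of no readable change.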

Compound 4, concentration for 50% growth inhibition: >= 20000 nM
Compound 4: no number, only a limit; the forecaster's own chance of this, stated with the estimate: 85%; the middle value sits exactly at the limit.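

In this assay compound 4 gives >= 20000 nM as a limit of the assay, not a number. For the compounds shown here, no step from compound 1, compound 2 or compound 3 to compound 4 can be read, because all four compounds sit at the same limit: the limit of >= 20000 nM in this assay, at which 4 of the 4 values shown sit. The compounds shown leave open how strongly any of them inhibits growth and whether changing the aromatic group on the sulfonyl sulfur alters that inhibition.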